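The compounds below may be only part of what the source reports. "The series", "measured", "known", "first", "only" and "open" are said of these compounds alone.

Three analogues sharing one core have been tested in a functional assay on ECa-109 cells for inhibition, with ECa-109 cell line (Homo sapiens) as the target, read by sulforhodamine B assay; a lower number here means a stronger inhibitor, a higher number a weaker inhibitor. Compound 1 `O=C1C=C(NCc2ccccc2)C(=O)c2c1nc1n2[C@H]2OC[C@@H](O)[C@H]2OC1` carries a benzylamino group on the quinone ring; in this assay compound 1 reaches only the limit of the assay, > 8000 nM, which is not a number. Compound 3 `COc1cccc(NC2=CC(=O)c3nc4n(c3C2=O)[C@H]2OC[C@@H](O)[C@H]2OC4)c1` carries a 3-methoxyanilino group, and in this assay compound 3 gives 7620 nM. For the measured compounds named here, the only measured step, an at least 1.0-fold lower number from compound 1 to compound 3 (0.02 log units; that floor lies within the scatter), rests on that limit of > 8000 nM in this assay, at which 1 of the 3 values shown sits, and says little. Compound 2 `O=C1C(Nc2ccccc2)=CC(=O)c2c1nc1n2[C@H]2OC[C@@H](O)[C@H]2OC1`, the plain anilino analogue, stands lowest of the two numbers in this assay with 3560 nM, and its gap to compound 3 lies beyond the scatter.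

Compound 4 `O=C1C(Nc2cccc(F)c2)=CC(=O)c2c1nc1n2[C@H]2OC[C@@H](O)[C@H]2OC1` differs from compound 2 by fluoro in place of hydrogen on an aromatic carbon. Going by the values given here, no measured step changes a hydrogen to fluoro on this ring, so no step bears directly on it; the one step available is of another kind and is bounded by a limit. The step of a 1.1-fold lower number from compound 2 to compound 4 (0.05 log units; within the scatter) is therefore expected to stay within the scatter, and compound 4 is estimated at 3200 nM, between 1200 nM and 8000 nM.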

Compound 4, half-maximal inhibitory concentration: 2370 nM
The estimate for compound 4 lay 1.4-fold (0.13 log units) above the measured number; the measured number falls inside the stated range.
By their numbers in this assay, from the lowest: compounds 4 and 2 (each within the scatter of the next); then compound 3. At a limit, above all of these: compound 1.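

The step of a 1.5-fold lower number from compound 2 to compound 4 (0.18 log units; within the scatter) shows that a fluoro group can sit on the anilino ring, meta to a large group, without moving the number in this assay beyond the scatter. For the compounds shown here, until now the only substituted ring was the 3-methoxyphenyl of compound 3, at 7620 nM, so a substituent at this place had been seen only with a number higher than that of the plain anilino compound 2; compound 4, at 2370 nM, does not share that gap. Nothing measured on these compounds accounts for this result.

As far as these compounds go, it remains open whether chloro, bromo or methyl at this place would also stay within the scatter of compound 2. From the compounds shown here alone, it is equally open what an amine or a carboxylic acid there would do to the number.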